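Trading pyridin-3-yl for (5-cyanopyridin-2-yl)oxy on a shared core

The compounds below may be only part of what the source reports. "The series", "measured", "known", "first", "only" and "open" are said of these compounds alone.

Measured so far in a physicochemical assay for lipophilicity (a higher number here means a more lipophilic compound, a lower number a more polar compound), for three compounds:
Compound 1 `CCn1cnc2c(-c3ccc(F)c(-c4cccnc4)c3)cnnc21` gives 2.6
Compound 2 `CCn1cnc2c(-c3ccnc(OC)c3)cnnc21` gives 1.5
Compound 3 `CCn1cnc2c(-c3ccnc(Oc4cccc(S(=O)(=O)CC)c4)c3)cnnc21` gives 1.6

In this assay compound 1 stands highest of the three, with 2.6 and a gap beyond the usual scatter to each of the other two. Compound 4 `CCn1cnc2c(-c3ccc(F)c(Oc4ccc(C#N)cn4)c3)cnnc21` keeps the core of compound 1 and its fluoro group, but carries (5-cyanopyridin-2-yl)oxy in place of pyridin-3-yl on an aromatic carbon, ortho to a fluoro group (5-cyanopyridin-2-yl)oxy in place of pyridin-3-yl on an aromatic carbon and meta to a large group. Among the measured compounds shown here, no measured pair isolates a swap like this one, so any forecast is loose. The closest hint comes from compound 3, which also holds a ring joined through an oxygen. Compound 3 with 1.6 lies within the scatter of compound 2 with 1.5 even though it is clearly the larger molecule, so added size need not shift this number much. The expected result is a number 0.10 log units higher from compound 1 to compound 4 (within the scatter) and this estimated shift stays within the scatter, with no firm direction. Compound 4 is estimated at 2.7 with a range from 2.2 to 3.2 expected.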

Compound 4, distribution coefficient: 2.3
Estimate against measurement, compound 4: 0.40 log units above, within the range that was stated.
By their numbers in this assay, from the lowest: compounds 2 and 3 (each within the scatter of the next); then compounds 4 and 1 (each within the scatter of the next).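

In this assay, among the compounds shown here, the only step that changes a single place is a number 0.30 log units lower from compound 1 to compound 4 (within the scatter), so on this aromatic carbon, ortho to a fluoro group and meta to a large group, the two groups cannot be told apart by this read-out. The swap is not a small one: (5-cyanopyridin-2-yl)oxy has more heavy atoms and more hydrogen-bond acceptors than pyridin-3-yl, and it adds an oxygen link and a nitrile. Yet the step still lies within the usual scatter, which is the first direct sign that this position can take such a change with no clear shift in the number. No outside measurement bears on this result, and it offers no explanation for the size of the step.

A single pair cannot show which part of the new group, the oxygen link, the nitrile or the ring itself, contributes what, and any of these could be hiding opposing shifts that happen to cancel. As far as these compounds go, whether a group of a different kind on this same carbon, such as a primary amine or a carboxylic acid, would move the number beyond the scatter remains open.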